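Moving the methoxy group: an estimate for compound 4

The source may hold more compounds than are shown below. What is called first, only, known or untested is meant among the compounds shown, and "the series" means these compounds.

In a functional assay on MGC-803 cells (Homo sapiens) for cytotoxicity, read by MTT assay, with a stated time of 72 h (on this read-out higher numbers stand for weaker inhibition and lower numbers for stronger inhibition), three compounds that share one core have been measured. Compound 1 `CN(C)c1ccc(C=C2C(=O)N(c3ccc(Cl)cc3)N(c3ccc(Cl)cc3)C2=O)cc1` gives 80200 nM, compound 2 `COc1cccc(C=C2C(=O)N(c3ccc(Cl)cc3)N(c3ccc(Cl)cc3)C2=O)c1O` gives 24300 nM, and compound 3 `COc1cccc(C=C2C(=O)N(c3ccc(Cl)cc3)N(c3ccc(Cl)cc3)C2=O)c1` gives 26600 nM. Compound 3 cannot be told apart from compound 2, and both show lower numbers than compound 1.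

Compound 4 `COc1ccccc1C=C1C(=O)N(c2ccc(Cl)cc2)N(c2ccc(Cl)cc2)C1=O` differs from compound 3 by one change: 2-methoxyphenyl in place of 3-methoxyphenyl on a double-bonded chain carbon bound to a double-bonded ring carbon. In words, it has 2-methoxyphenyl in place of 3-methoxyphenyl on a double-bonded chain carbon bound to a double-bonded ring carbon.

Within the data shown here, no measured step moves a methoxy group, so the evidence is indirect. Replacing the 4-(dimethylamino)phenyl group gave modest steps, a 3.0-fold lower number from compound 1 to compound 3 (0.48 log units; beyond the scatter) and a 3.3-fold lower number from compound 1 to compound 2 (0.52 log units; beyond the scatter). Replacing the hydroxy group with hydrogen gave a 1.1-fold higher number from compound 2 to compound 3 (0.04 log units; within the scatter). The two rings bearing a methoxy group thus gave matching numbers, so little change is expected here.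

The expected step is a 1.1-fold lower number from compound 3 to compound 4 (0.03 log units; within the scatter), which would stay within the scatter. The estimate for compound 4 is 25000 nM, with an expected range from 12000 nM to 55000 nM.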

Compound 4, half-maximal inhibitory concentration: 28600 nM
Compound 4: the middle estimate sits 1.1-fold (0.06 log units) below what was measured; measured number inside the range.
By their numbers in this assay, from the lowest: compounds 2, 3 and 4 (each within the scatter of the next); then compound 1.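

In this assay, the first measured move of the methoxy group gives a small step (a 1.1-fold higher number from compound 3 to compound 4 (0.03 log units; within the scatter)), so 2-methoxyphenyl and 3-methoxyphenyl cannot be told apart at this place, on a double-bonded chain carbon bound to a double-bonded ring carbon. Losing the hydroxy group together with the move also leaves the number within the scatter (a 1.2-fold higher number from compound 2 to compound 4 (0.07 log units; within the scatter)), whereas replacing 4-(dimethylamino)phenyl gives a step beyond it (a 2.8-fold lower number from compound 1 to compound 4 (0.45 log units; beyond the scatter)), so compound 1 alone stands apart among the four compounds. Nothing available explains why these rings give matching numbers.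

Going by these compounds, compound 1 and compound 4 differ in both the group and where it sits on the phenyl ring, so the share of each in that step remains unknown. Also open, on these data alone, is whether an ethoxy group, a carboxylic acid or a primary amine on this ring would give a clearly lower number.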